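This account rests on a few compounds, and the source may have more. Where it says the series, first, only, none or still open, it means among the compounds named here.

Compound 3 `C/C(=C\CC/C(C)=C/CC[C@@H]1[C@@]2(C)CCC(=O)C(C)(C)[C@H]2CC[C@@]1(C)O)CC/C=C(\C)C(=O)OCc1cn(-c2ccc(C(C)(C)C)cc2)nn1` carries a 4-(tert-butyl)phenyl group on an aromatic nitrogen. In a functional assay on A549 cells (Homo sapiens) for antiproliferative activity, read by MTT assay, with a stated time of 48 h (a lower number here means a stronger inhibitor, a higher number a weaker inhibitor), compound 3 gives > 150000 nM, which is a limit of the assay rather than a number. Compound 1 `C/C(=C\CC/C(C)=C/CC[C@@H]1[C@@]2(C)CCC(=O)C(C)(C)[C@H]2CC[C@@]1(C)O)CC/C=C(\C)C(=O)OCc1cn(-c2ccccc2C)nn1`, bearing 2-methylphenyl at the same place, gives > 150000 nM in this assay, again a limit. Compound 2 `C/C(=C\CC/C(C)=C/CC[C@@H]1[C@@]2(C)CCC(=O)C(C)(C)[C@H]2CC[C@@]1(C)O)CC/C=C(\C)C(=O)OCc1cn(-c2cccc(Cl)c2)nn1`, with 3-chlorophenyl there, gives 147000 nM in this assay. The step of an at least 1.0-fold higher number from compound 2 to compound 3 (0.00 log units; that floor lies within the scatter) and the step of an at least 1.0-fold lower number from compound 1 to compound 2 (0.00 log units; that floor lies within the scatter) both rest at their floor, and the step that the two limits leave unreadable from compound 1 to compound 3 cannot be read at all, since (the limit of > 150000 nM in this assay, at which 2 of the 3 values shown sit).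

Compound 4 `C/C(=C\CC/C(C)=C/CC[C@@H]1[C@@]2(C)CCC(=O)C(C)(C)[C@H]2CC[C@@]1(C)O)CC/C=C(\C)C(=O)OCc1cn(-c2ccccc2Br)nn1` differs from compound 3 in one place: 2-bromophenyl in place of 4-(tert-butyl)phenyl on an aromatic nitrogen. Every swap of the aromatic group seen so far has left the values at or close to the limit, so the expectation for the move to compound 4 is no step beyond the scatter, a number no higher from compound 3 to compound 4 (the limit leaves the size open). Compound 4 is therefore expected to give about 150000 nM in this assay, most likely again as a limit, with a range from 60000 nM to 400000 nM.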

Compound 4, half-maximal inhibitory concentration: > 150000 nM
Compound 4: only a limit was reported; the forecaster's own chance of this, stated with the estimate: 70%; the middle value lies on the limit itself.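

With 2-bromophenyl on the aromatic nitrogen, a bromine now sits on the same aromatic carbon that holds the methyl in compound 1, and in this assay this exchange brings no readable gain in activity. Going by these compounds alone, the one readable comparison, an at least 1.0-fold higher number from compound 2 to compound 4 (0.00 log units; that floor lies within the scatter), stays at its floor, so moving from the 3-chlorophenyl group to the 2-bromophenyl group shows no change beyond the scatter, and going down from the 10 heavy atoms of 4-(tert-butyl)phenyl to the 7 of 2-bromophenyl gives no visible benefit either. The steps from compound 1 and from compound 3 to compound 4 cannot be read because both ends of each are limits: the limit of > 150000 nM in this assay, at which 3 of the 4 values shown sit.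

Going by these compounds, whether an amine or a carboxylic acid on the phenyl ring, or a longer chain in place of that ring, would bring a value clearly under the limit remains open. On these data alone, how far the compounds at the limit differ from one another also remains unknown.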